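This account rests on a few compounds, and the source may have more. Where it says the series, first, only, none or still open, it means among the compounds named here.

Measured so far in an ADME assay on microsomes from liver (Mus musculus, strain CD-1) for metabolic stability, read by LC-MS, tested at 2 uM; a lower number here means that the compound disappears faster, a higher number that the compound lasts longer:
compound 1 `CNS(=O)(=O)c1ccccc1Nc1cc(-c2ccc3ccn(C)c3c2)c2nccnc2c1` — 0.2 h
compound 2 `Cn1ccc2ccc(-c3cc(Nc4ccccc4S(=O)(=O)N4CCOCC4)cc4nccnc34)cc21` — 0.367 h
compound 3 `Cn1cc(NC(=O)c2ccncc2Nc2cc(-c3ccc4ccn(C)c4c3)c3nccnc3c2)cn1` — 0.2 h

Compound 3 stands level with compound 1 at the digits shown, the two together the lowest of the three numbers; compound 2 sits a step away, a 1.8-fold higher number from compound 1 to compound 2 (0.26 log units; within the scatter), within the scatter. Going by the values given here, the only step measured so far is that one, morpholin-4-yl in place of methylamino on a sulfonyl sulfur, and it changed nothing beyond the scatter.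

Compound 4 `CN1CCC(CNC(=O)c2ccncc2Nc2cc(-c3ccc4ccn(C)c4c3)c3nccnc3c2)C1` differs from compound 3 by (1-methylpyrrolidin-3-yl)methyl in place of 1-methyl-1H-pyrazol-4-yl on an amide-type nitrogen. Among the compounds with values here, no measured step touches this amide-type nitrogen, so nothing in this assay supports a direction. The expectation for compound 4 is therefore a step of about a 1.5-fold higher number from compound 3 to compound 4 (0.18 log units; within the scatter), within the scatter. The estimate for compound 4 in this assay is 0.3 h, range 0.15 h to 0.6 h.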

Compound 4, half-life: > 1 h
Compound 4: only a limit was reported; the forecaster's own chance of this, stated with the estimate: 5%; at least 3.3-fold (0.52 log units) between middle value and limit.
By their numbers in this assay, from the lowest: compounds 1, 3 and 2 (each within the scatter of the next). At a limit, above all of these: compound 4.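

In this assay, going by these compounds alone, the amide-type nitrogen is the first place where a change goes beyond the scatter: (1-methylpyrrolidin-3-yl)methyl in place of 1-methyl-1H-pyrazol-4-yl gives an at least 5.0-fold higher number from compound 3 to compound 4 (0.69 log units; beyond the scatter). The step on the sulfonyl sulfur stayed within the scatter, so the amide substituent is the only place shown to move this read-out. Compound 4 reads only as a limit of the assay, so the step has a lower bound and no full size: the limit of > 1 h in this assay, at which 1 of the 4 values shown sits.

From the compounds shown here alone, whether the ring nitrogen of the entering group is needed stays open, and a cyclopentylmethyl on the same amide-type nitrogen would address that. Whether the aromatic ring or the added chain carbon accounts for the step also stays open.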